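A Chloro Analogue of Compound 2 Awaits Measurement

The source may report more compounds than this note shows. Statements on the series, on what has been measured and on what is new or still open speak of the compounds shown alone.

- compound 1 `Cc1cc(Nc2nc(NCc3ccccc3F)nc3[nH]ncc23)n[nH]1` in a functional assay on MCF7 cells (Homo sapiens) for inhibition, read by MTT assay, with a stated time of 5 days (a lower number here means a stronger inhibitor, a higher number a weaker inhibitor), gives 2310 nM
- compound 2 `Cc1cc(Nc2nc(NCc3ccccc3Br)nc3[nH]ncc23)n[nH]1` gives 14100 nM
- compound 3 `Cc1cc(Nc2nc(NCc3cccc(Cl)c3)nc3[nH]ncc23)n[nH]1` has not yet been measured

Of the two numbers in this assay, compound 2 holds the higher, at 14100 nM in this series. Compound 3 differs from it by 3-chlorophenyl in place of 2-bromophenyl on a saturated chain carbon bound to a nitrogen on an aromatic ring.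

Among the measured compounds shown here, only one measured step bears on this change. It is a 6.1-fold higher number from compound 1 to compound 2 (0.79 log units; beyond the scatter), with bromo in place of fluoro on an aromatic carbon, and it lies beyond the scatter. That step shows that the number can respond to a change in this group, but it is only a partial guide. For the measured compounds named here, no measured compound carries a chloro group or the 3-chlorophenyl group.

A modest move toward a lower number is therefore expected, since compound 2 stands at the top of a very small range. The estimated step is a 2.8-fold lower number from compound 2 to compound 3 (0.45 log units; beyond the scatter), though the uncertainty is wide. For compound 3 the estimated value is 5000 nM, with an expected range from 1500 nM to 16000 nM.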

Compound 3, half-maximal inhibitory concentration: 5620 nM
The estimate for compound 3 lay 1.1-fold (0.05 log units) below the measured number; the range from low to high includes it.
By their numbers in this assay, from the lowest: compound 1; then compound 3; then compound 2.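

In this assay, replacing 2-bromophenyl with 3-chlorophenyl on a saturated chain carbon bound to a nitrogen on an aromatic ring gives a 2.5-fold lower number from compound 2 to compound 3 (0.40 log units; beyond the scatter), while replacing 2-fluorophenyl with the same group gives a 2.4-fold higher number from compound 1 to compound 3 (0.39 log units; beyond the scatter), so the new group places its compound between the two earlier ones, with both steps beyond the scatter. This extends the earlier finding, which rested on a single exchange of bromo for fluoro on an aromatic carbon, but each new step changes both the halogen and the name of the ring group at once, so neither step can assign the shift to the chloro group alone or to its location on the ring. No supporting measurement is available to explain the order of the three compounds.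

The compounds shown leave open how 2-chlorophenyl, 3-bromophenyl or 3-fluorophenyl would compare at this place, and such groups would separate the halogen from its location. They also leave open whether an unsubstituted phenyl, a ring bearing an amine or a carboxylic acid, or a longer chain would give a lower number than any seen so far.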